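The compounds below may be only part of what the source reports. "The series", "measured", "known", "first", "only" and "open" are said of these compounds alone.

Working notes on the series, all read in a functional assay on MDA-MB-468 cells (Homo sapiens) for antiproliferative activity, read by MTT assay, with a stated time of 72 h; a higher number here means a weaker inhibitor, a lower number a stronger inhibitor. Compound 1 `COc1cc(-c2nccn2C(C)C)cc(OC)c1OC` stands at a limit of the assay with > 100000 nM as its reading. Compound 2 `CCCCCn1ccnc1-c1cc(OC)c(OC)c(OC)c1` gives 57900 nM and compound 3 `COc1cc(-c2nccn2-c2ccc(Br)cc2)cc(OC)c1OC` gives 2700 nM as the lowest number of the three.

All measured steps change the group on the aromatic nitrogen. They are an at least 1.7-fold lower number from compound 1 to compound 2 (0.23 log units; that floor lies within the scatter) with a floor inside the scatter, then an at least 37-fold lower number from compound 1 to compound 3 (1.56 log units; beyond the scatter) and a 21-fold lower number from compound 2 to compound 3 (1.33 log units; beyond the scatter) as the two large steps. Among these three compounds, the 4-bromophenyl group of compound 3 therefore goes with the lowest number.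

Compound 4 `COc1ccc(-n2ccnc2-c2cc(OC)c(OC)c(OC)c2)cc1` keeps that aromatic ring and changes only its substituent: methoxy in place of bromo on an aromatic carbon with methoxy in place of bromo on an aromatic carbon, para to a large group. Within the data shown here, no measured step changes a substituent at this place, so the large steps do not carry over in size. They only suggest that the aromatic ring itself is retained. The expectation rests on compound 3 at 2700 nM as the closest measured neighbour, and no step beyond the scatter is expected in this assay with no firm direction. The estimated step is a 1.4-fold lower number from compound 3 to compound 4 (0.13 log units; within the scatter) and the range stays wide on either side. For compound 4 the expected value is 2000 nM within an estimated range from 500 nM to 9000 nM.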

Compound 4, half-maximal inhibitory concentration: 500 nM
Estimate against measurement, compound 4: 4.0-fold (0.60 log units) above; the range from low to high includes it.
By their numbers in this assay, from the lowest: compound 4; then compound 3; then compound 2. At a limit, above all of these: compound 1.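

In this assay, among these compounds, the substituent on the aromatic ring now proves to matter in its own right: a 5.4-fold lower number from compound 3 to compound 4 (0.73 log units; beyond the scatter), for methoxy in place of bromo on an aromatic carbon, para to a large group, whereas the earlier steps only exchanged the whole group on the aromatic nitrogen. Set against the pentyl group, the 4-methoxyphenyl group gives a 120-fold lower number from compound 2 to compound 4 (2.06 log units; beyond the scatter), and compound 4 now holds the lowest number of the four, with each of its steps to the others beyond the scatter. Against the isopropyl group the reading is an at least 200-fold lower number from compound 1 to compound 4 (2.30 log units; beyond the scatter), but compound 1 stands at a limit, so this step is a floor and not a measured size: the limit of > 100000 nM in this assay, at which 1 of the 4 values shown sits.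

With only bromo and methoxy shown at this carbon, it stays open how a fluoro, a hydroxyl or a dimethylamino group would read in the same place. Also open, going by these compounds, is how far the shared core tolerates change with the 4-methoxyphenyl group kept, for instance an amine in place of one of its methoxy groups.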